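Swapping the dichlorophenyl for methoxyphenyl on a quinoxaline amine

The source may report more compounds than this note shows. Statements on the series, on what has been measured and on what is new or still open speak of the compounds shown alone.

Measured so far:
compound 1, `Nc1cc(N)c2nc(-c3ccccc3)c(NCc3ccc(Cl)c(Cl)c3)nc2c1`, 22400 nM
compound 2, `CCOC(=O)[C@H](CCC(=O)O)NC(=O)c1ccc(Sc2nc3cc(N)cc(N)c3nc2-c2ccccc2)cc1`, 17800 nM

Both numbers come from a functional assay on NCI-H226 cells (Homo sapiens) for inhibition, read by sulforhodamine B assay, with a stated time of 48 h; on this read-out higher numbers stand for weaker inhibition of growth and lower numbers for stronger inhibition of growth. Compound 1 gives 22400 nM and compound 2 gives 17800 nM; the two values lie within the usual scatter of each other, so neither can be called the more or less active of the pair. Both are weak inhibitors of growth on this cell line.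

Compound 3, `COc1ccc(CNc2nc3cc(N)cc(N)c3nc2-c2ccccc2)cc1`, has not yet been measured. It differs from compound 1 in one place: 4-methoxyphenyl in place of 3,4-dichlorophenyl on a saturated chain carbon bound to a nitrogen on an aromatic ring. Within the data shown here, nothing among the measured compounds shows what this kind of change does in this assay, so no step size can be read from the data. The expectation is a step from compound 1 to compound 3 of a 1.1-fold higher number from compound 1 to compound 3 (0.05 log units; within the scatter), that is, no change beyond the scatter. Compound 3 is therefore estimated at 25000 nM, with a range from 8000 nM to 70000 nM.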

Compound 3, concentration for 50% growth inhibition: 20400 nM
Estimate against measurement, compound 3: 1.2-fold (0.09 log units) above; measured number inside the range.
By their numbers in this assay, from the lowest: compounds 2, 3 and 1 (each within the scatter of the next).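

In this assay, putting 4-methoxyphenyl in place of 3,4-dichlorophenyl on a saturated chain carbon bound to a nitrogen on an aromatic ring gives a 1.1-fold lower number from compound 1 to compound 3 (0.04 log units; within the scatter) and so stays within the scatter. The earlier compounds shown here offered no step at this position, and this one shows that the assay does not separate these two groups, even though the two chlorine atoms are gone and a hydrogen-bond acceptor has entered. Nothing measured here accounts for the two groups reading alike.

From the compounds shown here alone, both groups compared keep a six-membered aromatic ring of carbon only, so it remains open what an amine or a carboxylic acid on that ring, or a longer chain in place of the single chain carbon, would do. Whether any group at this position can move the number beyond the scatter also stays unanswered.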